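The source may hold more compounds than are shown below. What is called first, only, known or untested is meant among the compounds shown, and "the series" means these compounds.

Three compounds share one core and were tested at a single concentration. Compound 1 `CN1CCN(CC(=O)Nc2ccc(-c3nc(-c4ccccc4)c(-c4ccccc4)n3C)cc2)CC1` gives 2.9% in a functional assay on MCF7 cells (Homo sapiens) for cytotoxicity, read by MTT assay, with a stated time of 24 h, tested at 1.6 ug/mL; on this read-out lower numbers stand for a weaker effect and higher numbers for a stronger effect at the one concentration tested. Compound 2 `CCN1CCN(CC(=O)Nc2ccc(-c3nc(-c4ccccc4)c(-c4ccccc4)n3C)cc2)CC1` gives 14.6%, and compound 3 `Cc1ccc(CN2CCN(CC(=O)Nc3ccc(-c4nc(-c5ccccc5)c(-c5ccccc5)n4C)cc3)CC2)cc1` gives 19.3%. Compound 3 holds the highest of the three numbers, yet its gap to compound 2 lies within the scatter, so those two cannot be ordered; only a number 11.7 percentage points higher from compound 1 to compound 2 (beyond the scatter) and a number 16.4 percentage points higher from compound 1 to compound 3 (beyond the scatter) reach beyond it. Compound 4 `COc1ccc(CN2CCN(CC(=O)Nc3ccc(-c4nc(-c5ccccc5)c(-c5ccccc5)n4C)cc3)CC2)cc1` differs from compound 3 by methoxy in place of methyl on an aromatic carbon. Among the measured compounds shown here, no measured step touches that aromatic ring: the earlier steps, including a number 4.7 percentage points higher from compound 2 to compound 3 (within the scatter), all change the group on the saturated chain carbon bound to the amine nitrogen in the ring. Nothing therefore points to a change beyond the scatter, and the expected step is a number 0.3 percentage points lower from compound 3 to compound 4 (within the scatter). Compound 4 is expected to give 19%, between 7% and 32%.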

Compound 4, a percentage reported as activity, at one concentration (the size of the read-out at that concentration, not a potency): 27.3%
Estimate against measurement, compound 4: 8.3 percentage points below; measured number inside the range.
By their numbers in this assay, from the lowest: compound 1; then compounds 2, 3 and 4 (each within the scatter of the next, the first and the last beyond it).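

Among the compounds shown here, the aromatic ring changes here for the first time, and methoxy in place of methyl on its carbon gives a number 8 percentage points higher from compound 3 to compound 4 (within the scatter) in this assay. Even so, 4-methoxyphenyl in place of methyl on the chain carbon gives a number 12.7 percentage points higher from compound 2 to compound 4 (beyond the scatter), a separation that 4-methylphenyl did not reach, and in place of hydrogen it gives a number 24.4 percentage points higher from compound 1 to compound 4 (beyond the scatter). No measurement at hand accounts for these numbers. As far as these compounds go, it remains open how a chlorine, a hydroxyl or an amine on this same aromatic carbon would read, and how these compounds would behave at other concentrations.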